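This account rests on a few compounds, and the source may have more. Where it says the series, first, only, none or still open, it means among the compounds named here.

Measured so far in an assay on isolated protein for inhibition of histone acetyltransferase p300 (Homo sapiens), with a stated time of 60 min; on this read-out higher numbers stand for weaker inhibition and lower numbers for stronger inhibition:
compound 1 `COc1ccc(NC(=O)[C@H]2CCCN2C(=O)C2(c3ccc(Cl)cc3)CCC2)cc1` gives 10 nM
compound 2 `N#Cc1ccc(C2(C(=O)N3CCC[C@@H]3C(=O)Nc3ccc4[nH]ncc4n3)CCC2)cc1` gives 0.251 nM
compound 3 `O=C(Nc1ccc2[nH]ncc2n1)[C@H]1CCCN1C(=O)C1(c2ccc(Cl)cc2)CCC1` gives 0.1 nM

Compound 3 has the lowest number of the three. The two steps that end at it are of very different size: a 100-fold lower number from compound 1 to compound 3 (2.00 log units; beyond the scatter), whereas a 2.5-fold lower number from compound 2 to compound 3 (0.40 log units; beyond the scatter). The first of these changes the amide-type nitrogen substituent and says nothing about the aromatic carbon at issue here; the second changes only the group on that aromatic carbon and is the one that bears on the next step.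

Compound 4 `COc1ccc(C2(C(=O)N3CCC[C@@H]3C(=O)Nc3ccc4[nH]ncc4n3)CCC2)cc1` keeps the core of compound 3 and differs from it in one place: methoxy in place of chloro on an aromatic carbon. For the measured compounds named here, no measured pair shows methoxy against chloro on that aromatic carbon directly; compound 1 carries methoxy there, but with a different amide-type nitrogen substituent, so its value against compound 3 cannot be split between the two changes. Going by the values given here, the only comparable exchange on this aromatic carbon, cyano for chloro, moved this assay by a modest amount, so a step of similar size is expected here, most likely toward a higher number, since compound 3 already holds the lowest value.

For compound 4 the expected step is a 3.0-fold higher number from compound 3 to compound 4 (0.48 log units; beyond the scatter), giving an estimate of 0.3 nM, with a range of 0.1 nM to 1 nM.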

Compound 4, half-maximal inhibitory concentration: 0.251 nM
Compound 4: middle estimate off by 1.2-fold (0.08 log units), on the high side; the measured number falls inside the stated range.
By their numbers in this assay, from the lowest: compound 3; then compounds 2 and 4 (each within the scatter of the next); then compound 1.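

In this assay, for the compounds shown here, the exchange of 4-chlorophenyl for 4-methoxyphenyl on the shared core gives a 2.5-fold higher number from compound 3 to compound 4 (0.40 log units; beyond the scatter) as the first direct reading of methoxy against chloro on this aromatic carbon, and it is no longer necessary to infer this exchange from the cyano pair or from compound 1. Methoxy read against cyano gives no change at the digits printed from compound 2 to compound 4 (within the scatter) and so does not separate these two groups, while chloro in place of cyano gives a 2.5-fold lower number from compound 2 to compound 3 (0.40 log units; beyond the scatter) and leaves chloro as the only one of the three groups set apart on this core. No measurement at hand accounts for this order of the groups.

From the compounds shown here alone, whether an amine, a carboxylic acid or a longer chain such as butoxy on this aromatic carbon would keep the number as low as that of compound 3 remains open. It is also open whether the step from chloro to methoxy would be of the same size with the amide-type nitrogen substituent of compound 1, since the compounds shown contain no pair that reads this exchange on that background.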